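A few compounds are considered here, and "the series" means these few. Any claim that something is new, unique, unknown or untested is made for them only; others in the source may bear on it.

Measured so far, in an ADME assay on HUVEC cells (Homo sapiens) for antiproliferative activity, read by MTT assay, with a stated time of 48 h; a lower number here means a stronger inhibitor, a higher number a weaker inhibitor:
- compound 1 `N#CC1=C(N)Oc2c(N)cc3nc4ccccc4nc3c2C12C(=O)N(Cc1cnnn1-c1cccc(Br)c1)c1ccccc12`: a limit only, > 50000 nM
- compound 2 `Cc1ccc(-n2nncc2CN2C(=O)C3(C(C#N)=C(N)Oc4c(N)cc5nc6ccccc6nc5c43)c3ccccc32)cc1C`: a limit only, > 50000 nM
- compound 3 `CCc1cccc(C)c1-n1nncc1CN1C(=O)C2(C(C#N)=C(N)Oc3c(N)cc4nc5ccccc5nc4c32)c2ccccc21`: a limit only, > 50000 nM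

Each of the three values is a limit of the assay and not a number; all three sit at the limit of > 50000 nM in this assay, at which 3 of the 3 values shown sit. Compound 3 therefore stands at the limit together with the other two, and no order among the three can be read. The steps among them, a step that the two limits leave unreadable from compound 1 to compound 2, a step that the two limits leave unreadable from compound 1 to compound 3 and a step that the two limits leave unreadable from compound 2 to compound 3, are each unreadable in size; both ends of each step are limits.

Compound 4 `N#CC1=C(N)Oc2c(N)cc3nc4ccccc4nc3c2C12C(=O)N(Cc1cnnn1-c1ccc(Cl)cc1[N+](=O)[O-])c1ccccc12` differs from compound 3 by 4-chloro-2-nitrophenyl in place of 2-ethyl-6-methylphenyl on an aromatic nitrogen. The three measured steps all exchange the group on the aromatic nitrogen, the same place that changes here, yet none of them yields a readable size, so they supply no direction and no magnitude to carry over. With all three measured values sitting at the limit of > 50000 nM in this assay, at which 3 of the 3 values shown sit, compound 4 is expected to return a limit again, and the step that the limit leaves unreadable from compound 3 to compound 4 is expected to stay within the scatter. For compound 4 the estimate in this assay is 60000 nM, with a range from 20000 nM to 200000 nM, most likely reported only as a limit.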

Compound 4, half-maximal inhibitory concentration: > 50000 nM
Compound 4: no number, only a limit; the forecaster's own chance of this, stated with the estimate: 85%; the middle value lies beyond the limit too.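

Compound 4 gives > 50000 nM in this assay, which is a limit and not a number. The steps joining compound 4 to compound 1, compound 2 and compound 3 cannot be read, and all four compounds share one limit: the limit of > 50000 nM in this assay, at which 4 of the 4 values shown sit.

The compounds shown leave open how the group on the aromatic nitrogen affects activity, and any order among the four.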